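The source may hold more compounds than are shown below. What is called first, only, known or untested is meant among the compounds shown, and "the series" means these compounds.

Of the compounds shown here, two have been measured so far in an ADME assay on liver for metabolic stability, with Liver microsome (Homo sapiens) as the target, read by LC-MS, using microsomes, with a stated time of 5 h; on this read-out higher numbers stand for fast clearance and lower numbers for slow clearance. Compound 1 `C[C@]1(O)C[C@](c2ccc(OC(F)(F)F)cc2)([C@H](O)c2ccccn2)C1` gives 50 mL/min/kg and compound 2 `C[C@]1(O)C[C@@](c2ccc(OC(F)(F)F)cc2)([C@H](O)c2ccccn2)C1` gives 66.7 mL/min/kg on this scale, so compound 2 stands within the usual scatter of compound 1. Within the data shown here, the only measured step is a 1.3-fold higher number from compound 1 to compound 2 (0.13 log units; within the scatter) and it comes with the fact that compounds 1 and 2 differ only in the configuration as drawn as the whole structural difference.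

Compound 3 `C[C@]1(O)C[C@@](c2ccc(OC(F)(F)F)cc2)([C@@H](O)c2ccccn2)C1` has not yet been measured. Its relation to compound 2 is the two compounds have the same atoms and bonds and differ only in configuration as drawn: 2 of 3 stereo elements differ; a stereocentre at a saturated ring carbon is drawn R in compound 2 and S in compound 3; a stereocentre at a saturated chain carbon is drawn S in compound 2 and R in compound 3 and no group leaves or enters. One of the two changed centres is the saturated ring carbon, a kind of centre that also changed in the measured pair. Among the measured compounds shown here, the other is the saturated chain carbon, which stayed the same between compound 1 and compound 2, so no measured step speaks to it directly. This leaves the forecast resting on thin evidence.

For the measured compounds named here, with a 1.3-fold higher number from compound 1 to compound 2 (0.13 log units; within the scatter) as the only guide, no step beyond the scatter is expected, and the estimated move is a 1.2-fold lower number from compound 2 to compound 3 (0.06 log units; within the scatter) in size. For compound 3 the expected value is 58 mL/min/kg with an estimated range of 30 mL/min/kg to 110 mL/min/kg on this read-out.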

Compound 3, clearance: 50 mL/min/kg
The estimate for compound 3 lay 1.2-fold (0.06 log units) above the measured number; measured number inside the range.
By their numbers in this assay, from the lowest: compounds 1, 3 and 2 (each within the scatter of the next).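

Among these compounds, the saturated chain carbon changes configuration here for the first time, together with the saturated ring carbon, and in this assay this gives a 1.3-fold lower number from compound 2 to compound 3 (0.13 log units; within the scatter). Compound 3 can also be set against compound 1, with the same chain carbon and the ring carbon again changed, and this gives no change at the digits printed from compound 1 to compound 3 (within the scatter). Together with the earlier step, this places all three arrangements within the scatter of one another, so configuration at these centres separates none of these compounds on this clearance read-out, and no group can be held responsible for the small gaps because no atom or bond changes: the fact that compounds 2 and 3 differ only in the configuration as drawn

Every pair shown changes two centres at once, so what either centre does alone stays open, and a real effect of one could in principle be offset by the other. Also open, from the compounds shown here alone, is whether the three arrangements would stay this close on a shared core that carries an amine or a carboxylic acid.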